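Amino for hydroxy on the catechol-bearing amide: compound 3

The source may report more compounds than this note shows. Statements on the series, on what has been measured and on what is new or still open speak of the compounds shown alone.

Measured so far in an ADME assay on NCI-H630 cells (Homo sapiens) for cytotoxicity, read by MTT assay, with a stated time of 72 h; a higher number here means that more compound is tolerated, a lower number that less compound is tolerated:
compound 1 `O=C(NCc1ccco1)c1cccc(O)c1O` – > 40000 nM
compound 2 `CN(C)Cc1ccc(C(=O)NCc2ccco2)c(O)c1O` – 7000 nM

Compound 1 stands at a limit of this assay, not at a number, as the limit of > 40000 nM in this assay, at which 1 of the 2 values shown sits, records. Compound 3 `Nc1cccc(C(=O)NCc2ccco2)c1O` is the unmeasured partner; it differs from compound 1 by amino in place of hydroxy on an aromatic carbon of the shared core.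

Among the compounds with values here, the only measured step is an at least 5.7-fold lower number from compound 1 to compound 2 (0.75 log units; beyond the scatter), which puts (dimethylamino)methyl on an aromatic carbon of compound 1. That change has no overlap with the amino-for-hydroxy exchange and therefore bears on the step to compound 3 only loosely. Within the data shown here, there is no measured pair in which hydroxy gives way to amino, so no size of step can be drawn from the data.

With nothing to move it, compound 3 is expected to stay close to where compound 1 sits, and the step of a number no higher from compound 1 to compound 3 (the limit leaves the size open) is estimated as within the scatter. The estimate for compound 3 is 40000 nM, with a range of 12000 nM to 100000 nM, and a limit rather than a number is thought likely.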

Compound 3, half-maximal cytotoxic concentration: > 25000 nM
Compound 3: a limit, no number; the forecaster's own chance of this, stated with the estimate: 60%; the middle value does not contradict the limit.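

In this assay compound 3 gives > 25000 nM, a limit and not a number. Compound 1 gives > 40000 nM, also a limit. Within the data shown here, no step between compound 1 and compound 3 can be read. The compounds shown leave open what amino in place of hydroxy on an aromatic carbon does to the number.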